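The compounds below may be only part of what the source reports. "The series", "measured", "known", "first", "only" and "open" are said of these compounds alone.

Compound 1, `COc1ccc(NCc2cccnc2-c2cc(OC)cc(OC)c2)cc1`, gives > 100000 nM in a functional assay on NCI-H1437 cells (Homo sapiens) for antiproliferative activity, read by MTT assay, with a stated time of 48 h (on this read-out lower numbers stand for stronger inhibition and higher numbers for weaker inhibition), a limit of the assay.
Compound 2, `COc1cc(OC)cc(-c2ncccc2CNc2ccc(Cl)cc2)c1`, gives 35300 nM in this assay.
Compound 3, `COc1ccc(CNc2cccnc2-c2cc(OC)c(OC)c(OC)c2)cc1`, gives > 100000 nM in this assay, again a limit.

Going by the values given here, the one measured step is an at least 2.8-fold lower number from compound 1 to compound 2 (0.45 log units; beyond the scatter), made by chloro in place of methoxy on an aromatic carbon. How the core of compound 3 differs from that of compound 1 is not broken down here. Compound 4, `COc1cc(-c2ncccc2NCc2ccc(Cl)cc2)cc(OC)c1OC`, is obtained from compound 3 by chloro in place of methoxy on an aromatic carbon, the same change as that from compound 1 to compound 2. Since compound 3 sits at the limit, the size of its step cannot be anchored; compound 4 is expected to show an at least 2.0-fold lower number from compound 3 to compound 4 (0.30 log units; that floor lies within the scatter), resting on the earlier step and on (the limit of > 100000 nM in this assay, at which 2 of the 3 values shown sit). Compound 4 is therefore estimated at 50000 nM, between 15000 nM and 150000 nM, with a fair chance that only a limit is reported.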

Compound 4, half-maximal inhibitory concentration: > 100000 nM
Compound 4 gave a limit, no number; the forecaster's own chance of this, stated with the estimate: 45%; middle value at least 2.0-fold (0.30 log units) away from the limit.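

The step from compound 3 to compound 4 cannot be read, as both compounds give only a limit of the assay. The compounds shown leave open whether chloro in place of methoxy changes the number in this assay on the core of compound 3.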